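Chloro in place of bromo: working notes toward compound 4

A few compounds are considered here, and "the series" means these few. Any claim that something is new, unique, unknown or untested is made for them only; others in the source may bear on it.

Measured so far:
compound 1 `NC(=O)/C=C1\CCc2c(F)cccc21`: 34%
compound 2 `CNC(=O)/C=C1\CCc2ccc(Br)cc21`: 53%
compound 3 `NC(=O)/C=C1\CCc2cc(Cl)ccc21`: 29%

In a functional assay on the whole organism with Rattus norvegicus as the target, at a dose of 20 mg/kg by the oral route (on this read-out lower numbers stand for less inhibition and higher numbers for more inhibition at the one dose given (going by the name of the read-out)), compound 2 gives 53%, the highest of the three numbers. Nearest to it is compound 1, whose number lies lower by a margin beyond the usual scatter; furthest is compound 3, whose number lies lower still, also beyond the scatter. No two of the measured compounds differ in one place only, so none of these gaps can be read as a single structural step.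

Compound 4 `CNC(=O)/C=C1\CCc2ccc(Cl)cc21` has not yet been measured. Against compound 2 the change is chloro in place of bromo on an aromatic carbon. Among the measured compounds shown here, with no single-step pair among the measured compounds, nothing shows how large a swap of one halogen for another moves the read-out. The expectation is therefore a step of modest size at most, downward if anything, and plausibly none beyond the scatter, with compound 2 as the anchor. The step expected is a number 7 percentage points lower from compound 2 to compound 4 (within the scatter), kept within the usual scatter. For compound 4 the estimate is 46%, with a range from 26% to 64%.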

Compound 4, a percentage reported as inhibition, in the whole organism at one dose (the size of the read-out at that dose, not a potency): 25%
Beside the measured number, compound 4's estimate is 21 percentage points above it; measured number below the stated range.
By their numbers in this assay, from the lowest: compounds 4, 3 and 1 (each within the scatter of the next); then compound 2.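

In this assay the series gains its first comparison that differs in one place only: a number 28 percentage points lower from compound 2 to compound 4 (beyond the scatter). This makes the aromatic carbon meta to a fused ring and para to a fused ring a place where chloro in place of bromo moves the read-out beyond the scatter, so the two halogens cannot be treated as interchangeable there on the core of compound 2. No measurement at hand bears on why the two halogens differ here, and the step stands as an observation from a single pair at a single oral dose.

From the compounds shown here alone, whether the read-out at this carbon tracks the halogen series or depends on bromo alone remains open, and iodo, methoxy, a nitrile or plain hydrogen at the same place would separate those readings. Also open, going by these compounds, is whether the same exchange gives a step of similar size with the unsubstituted amide in place of the methyl amide, or whether this step holds only for the amide of compound 2.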